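A few compounds are considered here, and "the series" means these few. Any claim that something is new, unique, unknown or untested is made for them only; others in the source may bear on it.

Series notes. The shared core of compound 1 `Cn1cc(-c2cnc(N)c(Oc3ccc(C(=O)Nc4ccccc4Cl)cc3)n2)cn1` carries an amide whose nitrogen bears a chloro-substituted aromatic ring; in a functional assay on HeLa cells (Homo sapiens) for inhibition, read by MTT assay, with a stated time of 72 h (a higher number here means a weaker inhibitor, a lower number a stronger inhibitor), compound 1 gives 73000 nM. Compound 2 `Cn1cc(-c2cnc(N)c(Oc3ccc(C(=O)Nc4cccc(Cl)c4)cc3)n2)cn1` gives 4460 nM, and compound 3 `Cn1cc(-c2cnc(N)c(Oc3ccc(C(=O)Nc4ccc(Cl)cn4)cc3)n2)cn1` gives 21500 nM, so compound 3 stands second highest of the three numbers, with a 3.4-fold lower number from compound 1 to compound 3 (0.53 log units; beyond the scatter) and a 4.8-fold higher number from compound 2 to compound 3 (0.68 log units; beyond the scatter). Compound 4 `Cn1cc(-c2cnc(N)c(Oc3ccc(C(=O)Nc4cc(Cl)ccn4)cc3)n2)cn1` differs from compound 3 by 4-chloropyridin-2-yl in place of 5-chloropyridin-2-yl on an amide-type nitrogen. Among the compounds with values here, no measured step moves chlorine within a pyridin-2-yl; the nearest guide is a 16-fold lower number from compound 1 to compound 2 (1.21 log units; beyond the scatter), which shows that where the chlorine sits on the amide-type ring can shift this assay strongly, and the direction for the pyridine case is unknown from these data. Compound 4 is therefore expected to show a 1.1-fold lower number from compound 3 to compound 4 (0.03 log units; within the scatter), an estimate of 20000 nM with a range from 4000 nM to 90000 nM.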

Compound 4, half-maximal inhibitory concentration: 40800 nM
Compound 4: middle estimate off by 2.0-fold (0.31 log units), on the low side; low and high end bracket the measured number.
By their numbers in this assay, from the lowest: compound 2; then compounds 3, 4 and 1 (each within the scatter of the next, the first and the last beyond it).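

In this assay the shift from 5-chloropyridin-2-yl to 4-chloropyridin-2-yl gives a 1.9-fold higher number from compound 3 to compound 4 (0.28 log units; within the scatter) and so, unlike the chlorine shift on the phenyl ring, does not separate the two groups. On the amide-type nitrogen, 4-chloropyridin-2-yl in place of 3-chlorophenyl gives a 9.1-fold higher number from compound 2 to compound 4 (0.96 log units; beyond the scatter) and in place of 2-chlorophenyl gives a 1.8-fold lower number from compound 1 to compound 4 (0.25 log units; within the scatter) which leaves 3-chlorophenyl as the best-placed group so far. Nothing available explains these steps. Still open, going by these compounds, is whether a methoxy group or an amine in place of the chlorine would keep these numbers. On these data alone, a 3-chloropyridine attachment also remains open.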